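The source may hold more compounds than are shown below. What is called first, only, known or untested is meant among the compounds shown, and "the series" means these compounds.

Working notes on the series.

Of the compounds shown here, three with the shared core of compound 1 have been measured. Compound 1 `CC(C)N1CCC(c2ccc3c(c2)oc(=O)n3C(=O)NCCCCc2ccccc2)CC1` gives 94 nM in an assay on HEK293 cells for inhibition of acid ceramidase (Homo sapiens), read by fluorescence, with stated times of 10 min and 3 h; a higher number here means a weaker inhibitor, a lower number a stronger inhibitor. Compound 2 `CC(=O)N1CCC(c2ccc3c(c2)oc(=O)n3C(=O)NCCCCc2ccccc2)CC1` gives 64 nM in this assay. Compound 3 `CN1CCN(c2ccc3c(c2)oc(=O)n3C(=O)NCCCCc2ccccc2)CC1` gives 116 nM in this assay, the highest of the three numbers, though both of its neighbours sit within the scatter of it.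

The steps that join the measured compounds are all small: a 1.5-fold lower number from compound 1 to compound 2 (0.17 log units; within the scatter); a 1.2-fold higher number from compound 1 to compound 3 (0.09 log units; within the scatter); a 1.8-fold higher number from compound 2 to compound 3 (0.26 log units; within the scatter). Neither the exchange of the group on the ring nitrogen nor the exchange of the whole saturated ring at the aromatic carbon has moved the number beyond the scatter.

Compound 4 `CN1CCC(c2ccc3c(c2)oc(=O)n3C(=O)NCCCCc2ccccc2)CC1` is not yet measured. It differs from compound 3 in one place: 1-methylpiperidin-4-yl in place of 4-methylpiperazin-1-yl on an aromatic carbon. Among the measured compounds shown here, the steps that bear on this are those from compound 1 and compound 2 to compound 3, which move the same position between the two kinds of saturated ring and stay within the scatter, and the step from compound 1 to compound 2, which changes the group on the ring nitrogen and also stays within the scatter. No step beyond the scatter is therefore expected in this assay.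

For compound 4 the expected value in this assay is 90 nM, with a range of 40 nM to 200 nM. The expected step is a 1.3-fold lower number from compound 3 to compound 4 (0.11 log units; within the scatter).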

Compound 4, half-maximal inhibitory concentration: 129 nM
The estimate for compound 4 lay 1.4-fold (0.16 log units) below the measured number; the range from low to high includes it.
By their numbers in this assay, from the lowest: compounds 2, 1, 3 and 4 (each within the scatter of the next).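

Among the compounds shown here, the pair of compound 3 and compound 4 carries a methyl on the ring nitrogen in both members, so it reads the ring exchange alone, which the earlier steps between the two kinds of saturated ring could not do because they also changed the group on that nitrogen: in this assay the replacement of 4-methylpiperazin-1-yl by 1-methylpiperidin-4-yl gives a 1.1-fold higher number from compound 3 to compound 4 (0.05 log units; within the scatter) for this change on the aromatic carbon. Methyl also adds a third group on the nitrogen of the piperidine ring, with a 2.0-fold higher number from compound 2 to compound 4 (0.30 log units; within the scatter) against acetyl and a 1.4-fold higher number from compound 1 to compound 4 (0.14 log units; within the scatter) against isopropyl, so none of the three groups on that nitrogen stands apart from the others in this assay. No supporting data are available to explain this flat response at the position.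

The compounds shown leave open whether the same flat response would hold with a benzyl group or a bare hydrogen on the ring nitrogen. They also leave open what a morpholin-4-yl ring or an open-chain amine would give on the same aromatic carbon, with the rest of the shared core kept unchanged.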